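Aryl replacement at the core in a receptor binding series

The source may hold more compounds than are shown below. What is called first, only, known or untested is meant among the compounds shown, and "the series" means these compounds.

Compound 3 `N#Cc1ccc(-c2nc(C(c3ccc(F)cc3)c3ccc(F)cc3)sc2CC(=O)O)cc1` sits second highest of the three numbers in an in vitro assay on HEK385-7 cells for displacement of a labelled ligand from prostaglandin D2 receptor 2 (Homo sapiens) (on this read-out lower numbers stand for stronger inhibition and higher numbers for weaker inhibition), where compound 3 gives 150 nM. Its nearest neighbour is compound 2 `O=C(O)Cc1sc(C(c2ccc(F)cc2)c2ccc(F)cc2)nc1-c1cc(F)cc(F)c1`, which in this assay gives 35 nM. The step of a 4.3-fold higher number from compound 2 to compound 3 (0.63 log units; beyond the scatter) lies beyond the scatter. Among the compounds with values here, the furthest of the measured set is compound 1 `O=C(O)Cc1sc(C(c2ccccc2)c2ccccn2)nc1-c1ccc(Cl)cc1`, which in this assay gives 810 nM; no single-place step connects compound 1 to the other two, so only the two values themselves can be set side by side.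

Compound 4 `O=C(O)Cc1sc(C(c2ccc(F)cc2)c2ccc(F)cc2)nc1-c1ccco1` follows from compound 3 by the change (furan-2-yl in place of 4-cyanophenyl on an aromatic carbon). Within the data shown here, the only measured step at the same position is a 4.3-fold higher number from compound 2 to compound 3 (0.63 log units; beyond the scatter), a modest step. Among the measured compounds shown here, no measured compound carries a furan-2-yl group at this position, so that step bears only loosely on the new change, and the direction of the new step cannot be read from the measured set. The expectation is therefore wide: compound 4 is estimated at 200 nM, with a range from 60 nM to 700 nM. The implied step a 1.3-fold higher number from compound 3 to compound 4 (0.12 log units; within the scatter) is expected to be small, with the direction uncertain.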

Compound 4, half-maximal inhibitory concentration: 18 nM
Compound 4: the middle estimate sits 11-fold (1.05 log units) above what was measured; the measured number lies below the stated range.
By their numbers in this assay, from the lowest: compounds 4 and 2 (each within the scatter of the next); then compound 3; then compound 1.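

Notes on the aryl position: in this assay, the position next to the ring nitrogen of the shared core does not need a six-membered aromatic ring of carbon, as a 1.9-fold lower number from compound 2 to compound 4 (0.29 log units; within the scatter) leaves furan-2-yl and 3,5-difluorophenyl inseparable there. The same furan-2-yl gives an 8.3-fold lower number from compound 3 to compound 4 (0.92 log units; beyond the scatter) against 4-cyanophenyl, and with a 4.3-fold higher number from compound 2 to compound 3 (0.63 log units; beyond the scatter) as the other step beyond the scatter, compound 3 stands apart from compound 2 and compound 4 at this position. Ring size alone therefore does not sort these three compounds, since compound 2 and compound 3 both carry a six-membered ring yet differ, and no measurement at hand offers an explanation for the gap.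

The compounds shown leave open whether the higher number of compound 3 goes with the nitrile itself or with the substituted phenyl ring that carries it, a question an unsubstituted phenyl would bear on directly. Going by these compounds, how far the tolerance for a five-membered ring extends is also open, for instance to a thiophene ring, an oxazole ring or a saturated ring such as cyclohexyl.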